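The source may hold more compounds than are shown below. What is called first, only, known or untested is meant among the compounds shown, and "the series" means these compounds.

Working notes on the series.

Two compounds carry numbers in an in vitro assay on LLC-PK1 cells for displacement of a labelled ligand from growth hormone secretagogue receptor type 1 (Homo sapiens); on this read-out higher numbers stand for weaker inhibition and lower numbers for stronger inhibition. Compound 1 `COc1ccc(Cn2c(CCc3c[nH]c4ccccc34)nnc2[C@H](NC(=O)c2ccccn2)c2c[nH]c3ccccc23)c(OC)c1` gives 1.8 nM, and compound 2 `COc1ccc(-n2c(CCc3ccccc3)nnc2[C@H](NC(=O)c2ccccn2)c2c[nH]c3ccccc23)c(OC)c1` gives 33 nM, the higher of the two numbers, the gap between them lying beyond the scatter. The two structures differ in more than one place, so the numbers alone do not say which change carries the gap.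

Compound 3 `COc1ccc(Cn2c(CCc3ccccc3)nnc2[C@H](NC(=O)c2ccccn2)c2c[nH]c3ccccc23)cc1` has not yet been measured. It differs from compound 2 in one place: 4-methoxybenzyl in place of 2,4-dimethoxyphenyl on an aromatic nitrogen. Compound 3 thus shares the phenethyl group of compound 2 while taking up a benzyl linkage, as in compound 1, between the aromatic nitrogen and the methoxy-bearing ring. Since compound 1 gives 1.8 nM with such a benzyl linkage, compound 3 is expected to move toward a lower number than compound 2, with a step of a 3.7-fold lower number from compound 2 to compound 3 (0.56 log units; beyond the scatter) judged plausible, though with wide uncertainty because compound 2 gives 33 nM with two changes in between. For compound 3 in this assay the estimate is 9 nM, within the range 2.5 nM to 35 nM.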

Compound 3, half-maximal inhibitory concentration: 0.7 nM
Estimate against measurement, compound 3: 13-fold (1.11 log units) above, outside the stated range (below it).
By their numbers in this assay, from the lowest: compound 3; then compound 1; then compound 2.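

In this assay, within the data shown here, 4-methoxybenzyl in place of 2,4-dimethoxyphenyl on an aromatic nitrogen gives a 47-fold lower number from compound 2 to compound 3 (1.67 log units; beyond the scatter) with the phenethyl group and the rest of the structure unchanged, the first step that can be read at a single place. The read-out therefore responds strongly to the group at this position, and the phenethyl group of compound 3 still allows a value of 0.7 nM in this series. Nothing on hand accounts for the size of this step, so it stands as an observation without an explanation.

The change brings in a benzyl linkage and removes a methoxy group at once, and the compounds shown do not separate these two parts, which 4-methoxyphenyl or 2,4-dimethoxybenzyl on the same nitrogen, with the phenethyl group kept, could do. Also open, from the compounds shown here alone, is how the read-out responds at this position to a longer chain such as 4-methoxyphenethyl, or to an amine such as dimethylaminoethyl.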